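The source may hold more compounds than are shown below. What is called first, only, known or untested is meant among the compounds shown, and "the series" means these compounds.

Of the compounds shown here, three have been tested so far in a functional assay on HepG2 cells (Homo sapiens) for inhibition, read by sulforhodamine B assay, with a stated time of 72 h (on this read-out higher numbers stand for weaker inhibition and lower numbers for stronger inhibition), and all of them show only weak inhibition. Compound 1 `C[C@H](Nc1nc(N)nc(N)c1C#N)c1nn(-c2cccc(S(C)(=O)=O)c2)c2cc(F)ccc12` gives 19100 nM. Compound 2 `C[C@H](Nc1ncnc2[nH]cnc12)c1nn(-c2cccnc2)c2ccc(F)cc12` gives 41900 nM. Compound 3 `C[C@H](Nc1ncnc2[nH]cnc12)c1nn(-c2cccnc2)c2cc(Cl)ccc12` gives > 40000 nM, which is a limit of this assay and not a number. Compound 3 therefore marks (the limit of > 40000 nM in this assay, at which 1 of the 3 values shown sits).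

Compound 4 `C[C@H](Nc1ncnc2[nH]cnc12)c1nn(-c2cccnc2)c2cc(F)ccc12` has not been measured yet. It is compound 3 with fluoro in place of chloro on an aromatic carbon, a swap counted as fluoro in place of chloro on an aromatic carbon. Within the data shown here, no two measured compounds differ in just one place, so there is no direct precedent for the size of this swap. Compound 3 offers only a limit, so it gives no exact starting point either.

The expectation therefore rests on the general level of the series, with compound 2 at 41900 nM and compound 1 at 19100 nM. No change beyond the usual scatter is expected in this assay, in either direction, and compound 4 could also return only a limit. The expected change is an at least 1.0-fold lower number from compound 3 to compound 4 (0.02 log units; that floor lies within the scatter). Compound 4 is estimated at 38000 nM, with an expected range from 17000 nM to 80000 nM.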

Compound 4, half-maximal inhibitory concentration: 37500 nM
For compound 4 the middle estimate is 1.0-fold (0.01 log units) above the measured one; measured number inside the range.
By their numbers in this assay, from the lowest: compounds 1, 4 and 2 (each within the scatter of the next, the first and the last beyond it).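

In this assay fluoro in place of chloro on this aromatic carbon, meta to a fused ring and para to a fused ring, gives an at least 1.0-fold lower number from compound 3 to compound 4 (0.02 log units; that floor lies within the scatter) as the first step read between two compounds that differ in one place. Compound 3 gives a limit of the assay and not a number, so this step is only a floor and its true size cannot be read: the limit of > 40000 nM in this assay, at which 1 of the 4 values shown sits. What compound 4 adds is an exact number of 37500 nM for this position, so further changes at this carbon would have a firm value to be compared with, which compound 3 could not provide.

The compounds shown leave open whether a different group on this carbon, such as methyl, methoxy or an amine, would shift the number beyond the usual scatter in either direction. They also leave open whether chloro and fluoro would give closer or more distant values on another core, such as the core of compound 1, where the other groups differ as well.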